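Mirror-Image Amine on a Receptor Binding Scaffold

This account rests on a few compounds, and the source may have more. Where it says the series, first, only, none or still open, it means among the compounds named here.

Compound 2 `N[C@@H]1CCN(CCCOc2ccc(-c3nc4ccc(Oc5ccc(Cl)cc5)cc4o3)cc2)C1` carries an amino-substituted saturated ring joined through a three-carbon linker to the shared core. Within the data shown here, in an assay on isolated protein for inhibition of advanced glycosylation end product-specific receptor (Homo sapiens), read by FRET, with stated times of 30 min and 1 h, tested at 4 uM (on this read-out lower numbers stand for less inhibition and higher numbers for more inhibition at the one concentration tested (going by the name of the read-out)), compound 2 gives 19.6%, the only number on hand; compound 1 `Clc1ccc(Oc2ccc3nc(-c4ccc(OCC5CCNCC5)cc4)oc3c2)cc1` is reported in this assay only as "not active" (no number reported), without a figure. Compound 3 `N[C@H]1CCN(CCCOc2ccc(-c3nc4ccc(Oc5ccc(Cl)cc5)cc4o3)cc2)C1` is the mirror-image form: the two compounds have the same atoms and bonds and differ only in configuration as drawn: 1 of 1 stereo elements differ; a stereocentre at a saturated ring carbon is drawn R in compound 2 and S in compound 3. Among the measured compounds shown here, no measured pair shows the weight of such a change here. The step from compound 2 to compound 3 is expected to stay within the scatter, a number 3.6 percentage points lower from compound 2 to compound 3 (within the scatter). Compound 3 is therefore estimated at 16%, between 0% and 34%.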

Compound 3, a percentage reported as inhibition, at one concentration (the size of the read-out at that concentration, not a potency): 29.9%
Estimate against measurement, compound 3: 13.9 percentage points below; the measured number falls inside the stated range.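

In this assay, the drawn configuration at this saturated ring carbon matters, if modestly: the change gives a number 10.3 percentage points higher from compound 2 to compound 3 (beyond the scatter). Among these compounds, this is the first number that can be tied to a single change, and the cause can be pinned on the stereocentre because nothing else varies: the fact that compounds 2 and 3 differ only in the configuration as drawn.

As far as these compounds go, whether the S form would still read higher with a longer chain, or with a dimethylamino group replacing the ring amine, stays open. A single tested concentration also gives no potency for either mirror-image form.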